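Fluoro-methoxyphenyl in Place of Hydroxyphenyl on a Shared Core

A few compounds are considered here, and "the series" means these few. Any claim that something is new, unique, unknown or untested is made for them only; others in the source may bear on it.

Compounds measured so far in a functional assay on KB cells (Homo sapiens) for antiproliferative activity, read by sulforhodamine B assay, with a stated time of 3 days; a higher number here means that more compound is needed for the effect, a lower number that less compound is needed:
compound 1, `CCC1=C(O)c2c(oc(-c3ccc(O)cc3)cc2=O)C(CC)(CC)C1=O`, gives 20.6 uM;
compound 2, `CCC1=C(O)c2c(oc(-c3ccc(COC)cc3)cc2=O)C(CC)(CC)C1=O`, gives only a limit, > 52.4 uM;
compound 3, `CCC1=C(O)c2c(oc(-c3ccc(OC)c(OC)c3)cc2=O)C(CC)(CC)C1=O`, gives 14.7 uM.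

Among the two numbers, compound 1 has the highest one, but compound 3 sits within the scatter of it, so the two cannot be ordered. Compound 4, `CCC1=C(O)c2c(oc(-c3ccc(OC)c(F)c3)cc2=O)C(CC)(CC)C1=O`, differs from compound 1 by 3-fluoro-4-methoxyphenyl in place of 4-hydroxyphenyl on an aromatic carbon. Among the measured compounds shown here, the one measured step that removes the hydroxy, an at least 2.5-fold higher number from compound 1 to compound 2 (0.40 log units; beyond the scatter), went toward a higher number in this assay, while compound 3, with methoxy groups, gives a number within the scatter of compound 1. A step toward a somewhat higher number is therefore expected, a 1.4-fold higher number from compound 1 to compound 4 (0.13 log units; within the scatter). For compound 4 the estimate in this assay is 28 uM, within a range from 11 uM to 60 uM.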

Compound 4, concentration for half-maximal effect: 26.7 uM
For compound 4 the middle estimate is 1.0-fold (0.02 log units) above the measured one; measured number inside the range.
By their numbers in this assay, from the lowest: compounds 3, 1 and 4 (each within the scatter of the next). At a limit, above all of these: compound 2.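

In this assay, losing the hydroxy does not by itself carry the number beyond the scatter: 3-fluoro-4-methoxyphenyl in place of 4-hydroxyphenyl on an aromatic carbon gives a 1.3-fold higher number from compound 1 to compound 4 (0.11 log units; within the scatter). Fluoro in place of methoxy on the same ring is equally unresolved, with a 1.8-fold higher number from compound 3 to compound 4 (0.26 log units; within the scatter). 3-Fluoro-4-methoxyphenyl in place of 4-(methoxymethyl)phenyl on an aromatic carbon gives an at least 1.9-fold lower number from compound 2 to compound 4 (0.29 log units; that floor lies within the scatter). Compound 2 gives only a limit, so that step is only a floor: the limit of > 52.4 uM in this assay, at which 1 of the 4 values shown sits.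

Still open, going by these compounds, is whether an amine or a carboxylic acid on this phenyl ring, or a longer chain in place of the methoxy, would move the number beyond the scatter.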